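A few compounds are considered here, and "the series" means these few. Any claim that something is new, unique, unknown or untested is made for them only; others in the source may bear on it.

Measured in a functional assay on U2OS cells for antagonist activity at C-X-C chemokine receptor type 3 (Homo sapiens), read by beta-arrestin recruitment; a lower number here means a stronger inhibitor, a higher number a weaker inhibitor:
- compound 1, `CCOc1ncc(-c2nc(C(F)(F)F)sc2N2CCN(C(=O)Cn3ccc4cccnc43)[C@H](C)C2)cn1`: 47 nM
- compound 2, `CCOc1ncc(-c2nc(C(F)(F)F)sc2N2CCN(C(=O)Cn3ncc4cccnc43)[C@H](C)C2)cn1`: 55 nM
- compound 3, `CCOc1ncc(-c2nc(C(F)(F)F)sc2N2CCN(C(=O)Cn3nc(C)cc3C)[C@H](C)C2)cn1`: 87 nM

Compound 3 gives the highest of the three numbers, yet both gaps stay within the scatter: a 1.9-fold higher number from compound 1 to compound 3 (0.27 log units; within the scatter) and a 1.6-fold higher number from compound 2 to compound 3 (0.20 log units; within the scatter). Compound 4, `CCOc1ncc(-c2nc(C(F)(F)F)sc2N2CCN(C(=O)Cn3ccc(C(F)(F)F)n3)[C@H](C)C2)cn1`, differs from compound 3 by 3-(trifluoromethyl)-1H-pyrazol-1-yl in place of 3,5-dimethyl-1H-pyrazol-1-yl on a saturated chain carbon bound to a carbonyl carbon. All measured steps swap the group on the saturated chain carbon bound to the carbonyl carbon, and none leaves the scatter, including a 1.2-fold higher number from compound 1 to compound 2 (0.07 log units; within the scatter). Going by the values given here, no measured step carries a trifluoromethyl on this pyrazole, so the new change is untested. The working expectation for compound 4 is therefore no step beyond the scatter, a 1.0-fold lower number from compound 3 to compound 4 (0.01 log units; within the scatter), with a wide range. Compound 4 is estimated at 85 nM, between 30 nM and 250 nM.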

Compound 4, half-maximal inhibitory concentration: 93 nM
Compound 4: middle estimate off by 1.1-fold (0.04 log units), on the low side, and the stated range covers the measured number.
By their numbers in this assay, from the lowest: compounds 1, 2, 3 and 4 (each within the scatter of the next).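

3-(trifluoromethyl)-1H-pyrazol-1-yl in place of 3,5-dimethyl-1H-pyrazol-1-yl on the saturated chain carbon gives a 1.1-fold higher number from compound 3 to compound 4 (0.03 log units; within the scatter), so this position accepts a trifluoromethyl on the pyrazole as readily as the two methyl groups. The wider comparisons, a 1.7-fold higher number from compound 2 to compound 4 (0.23 log units; within the scatter) and a 2.0-fold higher number from compound 1 to compound 4 (0.30 log units; within the scatter), also stay inside the scatter, leaving all four groups at this position unseparated. No supporting measurement bears on this result.

Open: whether an amine or a carboxylic acid on this pyrazole would move the number beyond the scatter. A longer chain in place of the saturated chain carbon also remains an open question.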